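This account rests on a few compounds, and the source may have more. Where it says the series, first, only, none or still open, it means among the compounds named here.

Compound 2 `COc1ccc(C(=O)/C=C/c2ccc(F)cc2)c2c1C=CC(C)(C)O2` carries a 4-fluorophenyl on the chain carbon next to the enone. In a functional assay on HCT-116 cells (Homo sapiens) for antiproliferative activity, read by MTT assay, with a stated time of 24 h (on this read-out higher numbers stand for weaker inhibition and lower numbers for stronger inhibition), compound 2 gives > 10000 nM, a limit of the assay rather than a number. Compound 1 `COc1cccc(/C=C/C(=O)c2ccc(OC)c3c2OC(C)(C)C=C3)c1` also sits at a limit in this assay, > 10000 nM. Compound 3 `COc1ccc(C(=O)/C=C/c2cccc(F)c2)c2c1C=CC(C)(C)O2` likewise returns a limit in this assay, > 10000 nM. In short, (the limit of > 10000 nM in this assay, at which 3 of the 3 values shown sit). The steps a step that the two limits leave unreadable from compound 1 to compound 2 and a step that the two limits leave unreadable from compound 2 to compound 3 therefore have no readable size, and a step that the two limits leave unreadable from compound 1 to compound 3 is equally unreadable. Compound 4 `COc1ccc(C(=O)/C=C/c2ccc(-c3ccccc3)cc2)c2c1C=CC(C)(C)O2` differs from compound 2 by phenyl in place of fluoro on an aromatic carbon. Within the data shown here, no measured step gives a readable size, so no direction can be drawn. Compound 4 is expected around 15000 nM, within 4000 nM to 60000 nM. The step that the limit leaves unreadable from compound 2 to compound 4 is an estimate only.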

Compound 4, half-maximal inhibitory concentration: > 10000 nM
Compound 4: a limit, no number; the forecaster's own chance of this, stated with the estimate: 70%; the middle value does not contradict the limit.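

Among these compounds, compound 2 and compound 4 both stay at a limit rather than a number, so no step between them can be read. Still open is whether any change to the shared core gives a number in this assay: the limit of > 10000 nM in this assay, at which 4 of the 4 values shown sit.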